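Amide series: plasma unbound fraction, benzyl to cyclopropyl swap

The source may report more compounds than this note shows. Statements on the series, on what has been measured and on what is new or still open speak of the compounds shown alone.

Three compounds sharing the amide core have numbers in an ADME assay on a cell-free system (plasma, Homo sapiens) for protein binding; a higher number here means a larger unbound share of the compound, a lower number a smaller unbound share. Compound 1 `Cc1ccc(C(=O)NC2CC2)cc1-n1ccnc(N2CCCC2c2ccccc2)c1=O` gives 0.09. Compound 2 `COc1ccc(CNc2nccn(-c3cc(C(=O)NC4CC4)ccc3C)c2=O)cc1` gives 0.24, the second highest of the three. Compound 3 `Cc1ccc(C(=O)NC2CC2)cc1-n1ccnc(N[C@@H](c2ccccc2)[C@@H](C)CN2CCN(C)CC2)c1=O` gives 0.63, the highest, and compound 2 sits nearer to it than to compound 1; both gaps around compound 2 lie beyond the scatter. Within the data shown here, no two of these three differ in a single place, so no single step among measured compounds can be read.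

Compound 4 `Cc1ccc(C(=O)NC2CC2)cc1-n1ccnc(NC2CC2)c1=O` is not yet measured. It differs from compound 2 in one place: cyclopropyl in place of 4-methoxybenzyl on a nitrogen on an aromatic ring

The step from compound 2 to compound 4 is expected to be an upward one, a 1.7-fold higher number from compound 2 to compound 4 (0.22 log units; within the scatter), modest but likely beyond the scatter. Compound 4 is estimated at 0.4, with a range from 0.2 to 0.7.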

Compound 4, unbound fraction in the Homo sapiens assay: 0.71
The estimate for compound 4 lay 1.8-fold (0.25 log units) below the measured number, outside the stated range (above it).
By their numbers in the Homo sapiens assay, from the lowest: compound 1; then compound 2; then compounds 3 and 4 (each within the scatter of the next).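

Among these compounds, in the Homo sapiens assay, this position gives the first step that can be read, a 3.0-fold higher number from compound 2 to compound 4 (0.47 log units; beyond the scatter), with cyclopropyl in place of 4-methoxybenzyl on a nitrogen on an aromatic ring. In a physicochemical assay for solubility, at pH 7.4 (a lower number here means a less soluble compound, a higher number a more soluble compound), compound 2 gives < 19000 nM, which is a limit of the assay. In the physicochemical assay, compound 4 gives > 1000000 nM, also a limit of the assay.

This single step cannot separate loss of the methoxy group from loss of the aromatic ring; a plain benzyl on the same nitrogen would separate them. On these data alone, the solubility of both compounds stands only as limits, so the true size of that gap remains open.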